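Swapping the Sulfonyl Aryl Group While Watching Liver-Cell Toxicity

The source may report more compounds than this note shows. Statements on the series, on what has been measured and on what is new or still open speak of the compounds shown alone.

Compound 1 `Cc1ccc(C)c(S(=O)(=O)Nc2ncc(C(Oc3ccc4cc(Br)ccc4c3)c3ccc(Cl)cc3)s2)c1`: > 50000 nM
Compound 2 `O=S(=O)(Nc1ncc(C(Oc2ccc3cc(Br)ccc3c2)c2ccc(Cl)cc2)s1)c1ccc2ccccc2c1`: > 50000 nM

In an ADME assay on HepG2 2.2.15 cells (Homo sapiens) for cytotoxicity (on this read-out higher numbers stand for lower toxicity in this test and lower numbers for higher toxicity in this test), compound 1 gives > 50000 nM, which is a limit of the assay and not a number. In this assay compound 2 gives > 50000 nM, likewise a limit. Between them lies the step that the two limits leave unreadable from compound 1 to compound 2, whose size cannot be read from two limits. Compound 2 therefore stands where every value so far stands, at the limit of > 50000 nM in this assay, at which 2 of the 2 values shown sit, and nothing separates it from compound 1 on the numbers shown.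

Compound 3 `O=S(=O)(Nc1ncc(C(Oc2ccc3cc(Br)ccc3c2)c2ccc(Cl)cc2)s1)c1cccc2nsnc12` differs from compound 2 by a group of 9 heavy atoms (6 carbon, 2 nitrogen, 1 sulfur; one five-membered aromatic ring with 3 hetero atoms, one six-membered aromatic ring of carbon only) in place of a group of 10 heavy atoms (10 carbon; 2 six-membered aromatic rings of carbon only), on a sulfonyl sulfur. Among the measured compounds shown here, the only measured step that touches this position is a step that the two limits leave unreadable from compound 1 to compound 2, and since it is unreadable it supports no expectation of a step in this assay of any particular size or direction; it shows only that two different aryl groups on the sulfonyl sulfur both ended at the limit. Compound 3 is accordingly expected at 60000 nM, with a range from 20000 nM to 200000 nM. The expected step is a step that the limit leaves unreadable from compound 2 to compound 3, and the most likely outcome is once more a limit rather than a number.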

Compound 3, half-maximal cytotoxic concentration: "not toxic" (no number reported)
The entry for compound 3 holds no number, and the estimate cannot be compared.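

Among the compounds shown here, compound 3 is recorded in this assay only as "not toxic", without a number, so no step from compound 2 to compound 3 can be read. The other two entries are limits and not numbers: the limit of > 50000 nM in this assay, at which 2 of the 3 values shown sit. The compounds shown leave open whether any aryl group on the sulfonyl sulfur changes the half-maximal cytotoxic concentration at all.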